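This account rests on a few compounds, and the source may have more. Where it says the series, first, only, none or still open, it means among the compounds named here.

Compound 1 `CCOC(=O)c1nn(-c2ccccc2)c(-c2ccc([N+](=O)[O-])cc2)c1CNC(C)(C)C`: > 591000 nM; 128000 nM (2 entries)
Compound 2 `CC(C)(C)NCc1c(C(=O)O)nn(-c2ccccc2)c1-c1ccc(Cl)cc1`: 145000 nM
Compound 3 `CC(C)(C)NCc1c(C(=O)O)nn(-c2ccccc2)c1-c1ccccc1`: > 716000 nM

All of these values come from a functional assay on PC-3 cells (Homo sapiens) for inhibition, read by sulforhodamine B assay, with a stated time of 48 h; a higher number here means a weaker inhibitor of growth, a lower number a stronger inhibitor of growth. In this assay compound 3 gives > 716000 nM, which is a limit and not a number. Compound 4 `CC(C)(C)NCc1c(C(=O)O)nn(-c2ccccc2)c1-c1ccc([N+](=O)[O-])cc1` has not yet been measured. It differs from compound 3 by a single change, (nitro in place of hydrogen on an aromatic carbon), which turns the phenyl into 4-nitrophenyl.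

Among the compounds with values here, one measured step bears directly on this: an at least 4.9-fold higher number from compound 2 to compound 3 (0.69 log units; beyond the scatter), hydrogen in place of chloro on an aromatic carbon, and it lies beyond the scatter. The change to compound 4 runs the other way, with nitro rather than chloro entering in place of hydrogen. Compound 1 offers a further reference, since it carries the same 4-nitrophenyl with an ethyl ester in place of the acid. Compound 1 gives > 591000 nM; 128000 nM (2 entries).

With compound 2 at 145000 nM as the closest guide, a lower number is expected, in a step of similar size to the chloro one. The expected step is an at least 3.9-fold lower number from compound 3 to compound 4 (0.59 log units; beyond the scatter). For compound 4 the estimate is 180000 nM, with an expected range from 60000 nM to 600000 nM.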

Compound 4, concentration for 50% growth inhibition: > 634000 nM
Compound 4: only a limit was reported (the forecaster's own chance of this, stated with the estimate: 30%); middle value at least 3.5-fold (0.54 log units) from the limit.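

In this assay compound 4 gives > 634000 nM, which is a limit of the assay and not a number, so the 4-nitrophenyl acid yields no measurable growth inhibition value. Nitro in place of chloro on this aromatic carbon, para to a large group, gives an at least 4.3-fold higher number from compound 2 to compound 4 (0.64 log units; beyond the scatter), which shows that the stronger result seen with chloro at this position does not carry over to nitro. Compound 3 and compound 4 each carry only a limit and the step between them cannot be read, and of the three acids only compound 2, with chloro, gives a number.

On these data alone, it remains open how far apart compound 3 and compound 4 really stand, and whether another group at this position, such as fluoro, methoxy or an amine, would give a number like that of compound 2. It is also open whether the ethyl ester of compound 1 differs from the carboxylic acid of compound 4, as the ester's two entries are a limit and a number: the several entries of compound 1 in this assay, > 591000 nM; 128000 nM (2 entries)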